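Swapping Methoxy for Methyl on a Side Chain

A few compounds are considered here, and "the series" means these few. Any claim that something is new, unique, unknown or untested is made for them only; others in the source may bear on it.

Measured compounds:
Compound 1 `CCC(COC)Oc1nc(C)nc2c1nnn2-c1ccc(C(C)C)cc1Br` gives 1.9 nM in an in vitro assay on 293-EBNA cells for binding affinity to corticotropin-releasing factor receptor 1 (Homo sapiens); a lower number here means a stronger inhibitor, a higher number a weaker inhibitor.
Compound 2 `COCC(COC)Oc1nc(C)nc2c1nnn2-c1ccc(C(C)C)cc1Br` gives 7.1 nM in this assay.
Compound 3 `CCC(COC)Oc1nc(C)nc2c1ncn2-c1ccc(C(C)C)cc1Br` gives 9.7 nM in this assay.

Compound 1 and compound 2 share one core and differ in a single spot: methyl in place of methoxy on a saturated chain carbon, two bonds along the chain from an oxygen on an aromatic ring. That change brought a 3.7-fold lower number from compound 2 to compound 1 (0.57 log units; beyond the scatter), a step that stands beyond the usual scatter. Compound 3 carries a different core; how that core differs from the core of compound 2 is not broken down here. Compound 3 sits at the highest of the three values, and its gap to compound 2 lies within the scatter, while its gap to compound 1 lies beyond it.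

Compound 4 `CCC(CC)Oc1nc(C)nc2c1ncn2-c1ccc(C(C)C)cc1Br` is not yet measured. It relates to compound 3 in the same way that compound 1 relates to compound 2: methyl in place of methoxy on a saturated chain carbon, two bonds along the chain from an oxygen on an aromatic ring, at the same place. Because the earlier step gave a 3.7-fold lower number from compound 2 to compound 1 (0.57 log units; beyond the scatter), a step of similar direction is expected here, estimated as a 2.8-fold lower number from compound 3 to compound 4 (0.44 log units; beyond the scatter). For compound 4 the expected value in this assay is 3.5 nM, with a likely range from 1.5 nM to 9 nM.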

Compound 4, inhibition constant: 3.5 nM
Estimate against measurement, compound 4: no gap at the digits printed, and the stated range covers the measured number.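

Replacing methoxy with methyl at this place turns the 1-(methoxymethyl)propoxy group of compound 3 into the (pentan-3-yl)oxy group of compound 4, and in this assay this gives a 2.8-fold lower number from compound 3 to compound 4 (0.44 log units; beyond the scatter) on a core different from that of the first pair. The two steps point the same way and match in size as closely as repeated measurements allow: the same change on two cores in this assay, a 3.7-fold lower number (0.57 log units; beyond the scatter) from compound 2 to compound 1 and a 2.8-fold lower number (0.44 log units; beyond the scatter) from compound 3 to compound 4, 1.3-fold (0.13 log units) apart, within the scatter of two such steps. In this series, then, the change carried over from one core to the other, but two pairs on two cores cannot show that it would carry to a third core, and they do not reveal why the number falls.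

The compounds shown leave open what other groups at this place would do, such as a hydroxyl, an amine or a longer chain like propyl in place of the methyl. They also leave open whether the step seen in this assay would appear in any other kind of test.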